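Alkyl growth on the core: compound 3 to compound 4

A few compounds are considered here, and "the series" means these few. Any claim that something is new, unique, unknown or untested is made for them only; others in the source may bear on it.

Measured compounds:
compound 1 `Cc1c(Nc2ccc(S(C)(=O)=O)cc2F)ncnc1O[C@H]1CC[C@]2(CC1)COC(C)(C)C2` gives 91%
compound 2 `Cc1c(Oc2ccc(S(C)(=O)=O)cc2F)ncnc1O[C@H]1CC[C@]2(CC1)COC(C)(C)C2` gives 62%
compound 3 `CCc1c(Nc2ccc(S(C)(=O)=O)cc2F)ncnc1O[C@H]1CC[C@]2(CC1)COC(C)(C)C2` gives 82%

In a functional assay on HEK293 cells with Glucose-dependent insulinotropic receptor (Homo sapiens) as the target, read by HTRF and cAMP accumulation, with a stated time of 30 min (on this read-out lower numbers stand for smaller maximal responses and higher numbers for larger maximal responses), compound 3 stands second highest of the three numbers. Its nearest neighbour is compound 1, at a value that lies within the scatter of compound 3; the furthest is compound 2, whose lower value lies beyond the scatter of compound 3. For the measured compounds named here, no step is computed for the pair of compound 2 and compound 3, so only the two values themselves speak for it.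

Compound 4 `CC(C)c1c(Nc2ccc(S(C)(=O)=O)cc2F)ncnc1O[C@H]1CC[C@]2(CC1)COC(C)(C)C2` differs from compound 3 by methyl in place of hydrogen on a saturated chain carbon bound to an aromatic carbon and a saturated chain carbon. The same difference, cut one bond further out, reads ethyl to isopropyl. Going by the values given here, the only measured step that bears on it is a number 9 percentage points lower from compound 1 to compound 3 (within the scatter), the same kind of change one bond closer in, and it stayed within the scatter. Among the compounds with values here, no other pair carries this change.

The expectation is therefore a small step, if any downward, not beyond the scatter: a number 7 percentage points lower from compound 3 to compound 4 (within the scatter) is estimated. Compound 4 is expected to give 75%, with a range from 60% to 88%.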

Compound 4, intrinsic activity: the largest response reached, in percent of the reference agonist's in the Glucose-dependent insulinotropic receptor assay: 61%
Compound 4: the middle estimate sits 14 percentage points above what was measured; the measured number falls inside the stated range.
By their numbers in the Glucose-dependent insulinotropic receptor assay, from the lowest: compounds 4 and 2 (each within the scatter of the next); then compounds 3 and 1 (each within the scatter of the next).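

In the Glucose-dependent insulinotropic receptor assay, methyl in place of hydrogen on this saturated chain carbon gives a number 21 percentage points lower from compound 3 to compound 4 (beyond the scatter), whereas the earlier methyl in place of hydrogen, on the carbon bound to the aromatic carbon alone, gave a number 9 percentage points lower from compound 1 to compound 3 (within the scatter). Set against the methyl group of compound 1, isopropyl gives a number 30 percentage points lower from compound 1 to compound 4 (beyond the scatter), so among these three compounds ethyl stays within the scatter of methyl and only isopropyl falls beyond it. In a physicochemical assay for solubility, at pH 1.2 (on this read-out lower numbers stand for lower solubility and higher numbers for higher solubility), compound 3 gives 4600 nM and compound 4 gives 700 nM, so the same change also comes with a lower solubility: the measured solubility of compound 3, 4600 nM, and of compound 4, 700 nM, a 6.6-fold lower number (0.82 log units; beyond the scatter)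

Still open, going by these compounds, is whether a straight propyl chain or a cyclopropyl group here would keep the response of compound 3, which would separate branching on this carbon from the added carbon alone. Also open, on these data alone, is how a methoxymethyl group or an amine on this chain would read in either assay.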